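This account rests on a few compounds, and the source may have more. Where it says the series, first, only, none or still open, it means among the compounds named here.

Working notes on the series. Among the compounds with values here, compound 1 `COc1ccc(/C=C2/CN(C)/C(=N/c3ccc(C)cc3)S2)cc1` is the one member with a numbered result: in a functional assay on MCF7 cells (Homo sapiens) for antiproliferative activity, read by MTT assay, with a stated time of 72 h (a higher number here means a weaker inhibitor, a lower number a stronger inhibitor), compound 1 gives 7600 nM. Compound 2 `C=C1CN/C(=N/c2ccccc2)S1` is recorded only as a limit, and in this assay compound 2 gives > 100000 nM. Compound 3 `COc1ccc(/C=C2\S/C(=N\c3ccc(C(C)(C)C)cc3)N(C)C2=O)cc1` is likewise recorded only as a limit, and in this assay compound 3 gives > 100000 nM. Within the data shown here, the state of the data is thus (the limit of > 100000 nM in this assay, at which 2 of the 3 values shown sit), and compound 1 stands alone as the single compound with a value that can be compared; no step between measured compounds can be drawn from these three, so nothing here tells how any change on the outer ring moves the result.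

Compound 4 `COc1ccc(/C=C2/CN(C)/C(=N/c3ccc(F)cc3)S2)cc1` has not yet been measured in this assay. It differs from compound 1 by fluoro in place of methyl on an aromatic carbon. Among the measured compounds shown here, with no measured step of this kind to lean on, the expectation for this assay is a small step, of a size within or only slightly beyond the scatter, and with a slight lean toward a weaker inhibitor. Compound 4 is therefore expected to give about 11000 nM in this assay, with a plausible range from 3500 nM to 40000 nM. This amounts to an expected step of a 1.4-fold higher number from compound 1 to compound 4 (0.16 log units; within the scatter) in this assay.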

Compound 4, half-maximal inhibitory concentration: 8000 nM
The estimate for compound 4 lay 1.4-fold (0.14 log units) above the measured number, within the range that was stated.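

Fluoro in place of methyl on this aromatic carbon, para to a large group, gives a 1.1-fold higher number from compound 1 to compound 4 (0.02 log units; within the scatter) in this assay, and this is the first step in the series that can be read. The 4-methylphenyl to 4-fluorophenyl exchange therefore does not separate compound 1 from compound 4 in this assay, and neither compound can be ranked above the other, so this position on the shared core accepts either group with no change beyond the scatter. Nothing on hand gives a cause for this step.

The compounds shown leave open whether a different kind of group at this position, such as an amine, a carboxylic acid or a longer alkyl chain, would move the result beyond the scatter, since only methyl and fluoro have been compared here on this core. Steps that would link compound 2 or compound 3 to the others cannot be read, so what separates those two compounds from compound 1 and compound 4 also remains open.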